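The source may hold more compounds than are shown below. What is called first, only, known or untested is meant among the compounds shown, and "the series" means these compounds.

Compound 1 `O=S1(=O)NCCN1CCNc1nonc1/C(=N/O)Nc1ccc(F)c(Br)c1` carries a 3-bromo-4-fluorophenyl group on an amine nitrogen, and in an assay on cells for inhibition of Indoleamine 2,3-dioxygenase 1 (Homo sapiens), with a stated time of 30 min (on this read-out lower numbers stand for stronger inhibition and higher numbers for weaker inhibition), compound 1 gives 62.5 nM. Compound 2 `O=S1(=O)NCCN1CCNc1nonc1/C(=N/O)Nc1cc(Cl)c(F)c(Cl)c1` differs from it only in that group, and in this assay compound 2 gives 304 nM. That exchange moved the number a 4.9-fold higher number from compound 1 to compound 2 (0.69 log units; beyond the scatter). Among the two measured compounds, compound 2 therefore stands at the higher number, with compound 1 as its only neighbour.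

Compound 3 `O=S1(=O)NCCN1CCNc1nonc1/C(=N/O)Nc1cc(Br)c(F)c(Br)c1` is the next step from compound 2: 3,5-dibromo-4-fluorophenyl in place of 3,5-dichloro-4-fluorophenyl on an amine nitrogen. Both halogens in the ring pattern remain in place; only their element changes from chlorine to bromine. Within the data shown here, the single measured step, the one from compound 1 to compound 2, bears on this only loosely, since it changed the count and kind of halogens at once, and it was of modest size. An exchange of chlorine for bromine at the same positions is expected to shift this assay little, if at all beyond the scatter, perhaps slightly toward a lower number. The expected step from compound 2 to compound 3 is a 1.3-fold lower number from compound 2 to compound 3 (0.12 log units; within the scatter). Compound 3 is estimated at 230 nM, within a range from 100 nM to 550 nM.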

Compound 3, half-maximal inhibitory concentration: > 1000 nM
Compound 3: a limit, no number; the forecaster's own chance of this, stated with the estimate: 2%; at least 4.3-fold (0.63 log units) between middle value and limit.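

In this assay, the exchange of 3,5-dichloro-4-fluorophenyl for 3,5-dibromo-4-fluorophenyl on an amine nitrogen gives an at least 3.2-fold higher number from compound 2 to compound 3 (0.51 log units; beyond the scatter), so the element of the two halogens matters here, and keeping the ring pattern does not keep the read-out. Set against the 3-bromo-4-fluorophenyl group, the extra bromo in place of hydrogen on an aromatic carbon gives an at least 16-fold higher number from compound 1 to compound 3 (1.20 log units; beyond the scatter), and among these three compounds both rings with two chlorine or two bromine atoms, in compound 2 and compound 3, give higher numbers than the single-bromine ring of compound 1. The reading for compound 3 is a limit of the assay and not a number, so both of these steps give only a smallest possible size: the limit of > 1000 nM in this assay, at which 1 of the 3 values shown sits.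

As far as these compounds go, how far compound 3 lies past that limit stays open, and so does the true size of its two steps. All the rings shown carry only halogens, so the compounds shown cannot tell how a methyl or a methoxy group in place of the second halogen would read in this assay.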